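A few compounds are considered here, and "the series" means these few. Any claim that something is new, unique, unknown or untested is made for them only; others in the source may bear on it.

Compound 1 `CC(C)(N)C(=O)N[C@H](COCc1ccc(F)cc1F)c1nnnn1CCOC(=O)NCCCCO`: 0.42 nM
Compound 2 `CC(C)(N)C(=O)N[C@H](COCc1cccc(C(F)(F)F)c1)c1nnnn1CCOC(=O)NCCCCO`: 1.79 nM

Among the measured compounds shown here, in a functional assay on cells for inhibition of growth hormone secretagogue receptor type 1 (Homo sapiens), read by FLIPR and calcium flux (a higher number here means that more compound is needed for the effect, a lower number that less compound is needed), compound 2 stands highest of the two measured compounds, the only step being a 4.3-fold higher number from compound 1 to compound 2 (0.63 log units; beyond the scatter). Compound 3 `CC(C)(N)C(=O)N[C@H](COCc1cccc(OC(F)(F)F)c1)c1nnnn1CCOC(=O)NCCCCO` differs from compound 2 by trifluoromethoxy in place of trifluoromethyl on an aromatic carbon. For the measured compounds named here, no measured step changes the same part of the molecule, and the one step at hand swapped a whole ring pattern rather than one group, so it gives only a loose guide. A small change in this assay is expected for compound 3, of size a 1.4-fold higher number from compound 2 to compound 3 (0.15 log units; within the scatter), not clearly beyond the scatter. Compound 3 is therefore estimated at 2.5 nM, within 0.9 nM to 7 nM.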

Compound 3, half-maximal effective concentration: 3.1 nM
For compound 3 the middle estimate is 1.2-fold (0.09 log units) below the measured one; low and high end bracket the measured number.
By their numbers in this assay, from the lowest: compound 1; then compounds 2 and 3 (each within the scatter of the next).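

Trading trifluoromethyl for trifluoromethoxy on this aromatic carbon gives a 1.7-fold higher number from compound 2 to compound 3 (0.24 log units; within the scatter) in this assay, so the added oxygen does not clearly separate the two groups here. The 2,4-difluorophenyl group of compound 1 still stands apart, with a 7.4-fold higher number from compound 1 to compound 3 (0.87 log units; beyond the scatter) as the step to the new compound. No measurement available here accounts for these numbers. Still open, on these data alone, is how a methoxy group or a nitrile would read at this place on the ring. Also open, as far as these compounds go, is whether the gap to compound 1 follows from the kind of group or from where it sits.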